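Trading Trifluoromethyl for Methyl in Compound 4

A few compounds are considered here, and "the series" means these few. Any claim that something is new, unique, unknown or untested is made for them only; others in the source may bear on it.

Of the compounds shown here, three built on one shared core have been measured in a functional assay on Huh-7 cells (Homo sapiens) for inhibition, read by sulforhodamine B assay, with a stated time of 72 h; on this read-out lower numbers stand for stronger inhibition and higher numbers for weaker inhibition. Compound 1 `CC(C)Cc1ccc(C(C)c2nnc3n2N=C(c2ccc(Cl)cc2)CS3)cc1` gives 5700 nM, compound 3 `COc1ccc(C2=Nn3c(nnc3C(C)c3ccc4cc(OC)ccc4c3)SC2)cc1` gives 8500 nM, and compound 2 `CC(c1ccc(-c2ccccc2)c(F)c1)c1nnc2n1N=C(c1ccc(C(F)(F)F)cc1)CS2` gives 9400 nM. Compound 2 lies within the usual scatter of both compound 3 and compound 1, so these three numbers cannot be told apart. Compound 4 `Cc1ccc(C2=Nn3c(nnc3C(C)c3ccc(-c4ccccc4)c(F)c3)SC2)cc1` differs from compound 2 by a single change, (methyl in place of trifluoromethyl on an aromatic carbon), methyl in place of trifluoromethyl on an aromatic carbon. Within the data shown here, no measured pair shows this exchange, so nothing in these data fixes its size or direction. Compound 4 is estimated at 8000 nM in this assay, with a range from 3000 nM to 20000 nM. That estimate means an expected step of a 1.2-fold lower number from compound 2 to compound 4 (0.07 log units; within the scatter), nothing beyond the scatter.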

Compound 4, half-maximal inhibitory concentration: 7200 nM
Estimate against measurement, compound 4: 1.1-fold (0.05 log units) above; the range from low to high includes it.
By their numbers in this assay, from the lowest: compounds 1, 4, 3 and 2 (each within the scatter of the next).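

In this assay, among these compounds, methyl in place of trifluoromethyl on this aromatic carbon, para to a large group, gives the first direct reading of this exchange (a 1.3-fold lower number from compound 2 to compound 4 (0.12 log units; within the scatter)). In this single pair, the 4-(trifluoromethyl)phenyl and 4-methylphenyl compounds cannot be told apart. Nothing available offers an explanation for this result.

The compounds shown leave open whether an amine or a carboxylic acid on this carbon would move the number beyond the scatter. They also leave open whether this exchange would read the same with another group elsewhere on the shared core.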